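The compounds below may be only part of what the source reports. "The series", "measured", "known", "first", "only" and "open" are said of these compounds alone.

Measured in a functional assay on HT-29 cells (Homo sapiens) for cytotoxicity, read by MTT assay, with a stated time of 72 h; on this read-out lower numbers stand for stronger inhibition and higher numbers for weaker inhibition:

compound 1, `COc1ccc(-c2cc(/N=C3/NC(=O)CS3)cs2)cc1`: > 50000 nM (a limit of the assay)
compound 2, `O=C1CS/C(=N\c2csc(-c3ccc(Cl)cc3)c2)N1`: 17100 nM
compound 3, `COc1ccc(/C=C2\S/C(=N\c3csc(-c4ccc(Cl)cc4)c3)NC2=O)cc1`: 3800 nM

Compound 2 holds the highest of the two numbers in this assay; compound 3 sits at a lower number. Compound 1 shows only a limit, (the limit of > 50000 nM in this assay, at which 1 of the 3 values shown sits), so it is not a number. Within the data shown here, the single measured step on the shared core, an at least 2.9-fold lower number from compound 1 to compound 2 (0.46 log units; beyond the scatter), concerns the substituent on the pendant aromatic ring and not the ring amide nitrogen.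

Compound 4, `COc1cccc(N2C(=O)CS/C2=N\c2csc(-c3ccc(Cl)cc3)c2)c1`, differs from compound 2 at one place: 3-methoxyphenyl in place of hydrogen on an amide-type nitrogen in a ring. Among the measured compounds shown here, no measured step touches this nitrogen, so the step from compound 2 to compound 4 has no direct precedent among the measured compounds. The values of compound 2 and compound 3 show that adding an aromatic group elsewhere on the core went with a lower number, but that change is at a different site. A modest lowering in this assay, a 2.1-fold lower number from compound 2 to compound 4 (0.33 log units; beyond the scatter), is expected, with wide uncertainty. Compound 4 is therefore estimated at 8000 nM, within a range from 2000 nM to 40000 nM.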

Compound 4, half-maximal inhibitory concentration: 24600 nM
Beside the measured number, compound 4's estimate is 3.1-fold (0.49 log units) below it, and the stated range covers the measured number.
By their numbers in this assay, from the lowest: compound 3; then compounds 2 and 4 (each within the scatter of the next). At a limit, above all of these: compound 1.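

In this assay, among these compounds, 3-methoxyphenyl in place of hydrogen on the amide-type nitrogen in the ring gives a 1.4-fold higher number from compound 2 to compound 4 (0.16 log units; within the scatter), which is the first reading at this nitrogen. The amide hydrogen can therefore be exchanged here for a group with a six-membered aromatic ring of carbon only without a shift beyond the scatter, though this rests on a single pair of compounds. Nothing measured here bears on why the number stays within the scatter after this change.

Going by these compounds, whether methyl, a longer alkyl chain, an amine or a carboxylic acid on this nitrogen would read the same remains open. Also open, on these data alone, is how 3-methoxyphenyl on this nitrogen reads when combined with the aromatic group elsewhere on the core that compound 3 carries (3800 nM).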